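A few compounds are considered here, and "the series" means these few. Any claim that something is new, unique, unknown or untested is made for them only; others in the source may bear on it.

Four related compounds make up this small series. Compound 1 `COc1cccc(/C(=C\c2cn(C(C)=O)c3ccc(OCc4ccccc4)cc23)C(=O)O)c1` carries a methoxy group on one aromatic ring and an acetyl group on the ring nitrogen of the shared core; in a functional assay on LNCaP cells (Homo sapiens) for cytotoxicity, read by MTT assay, with a stated time of 72 h (a lower number here means a stronger inhibitor, a higher number a weaker inhibitor), compound 1 gives 65100 nM. Compound 2 `COc1ccc(/C(=C\c2c[nH]c3ccc(OCc4ccccc4)cc23)C(=O)O)cc1` lacks that acetyl group, and in this assay compound 2 gives "not determined" (no result reported), so no number was obtained for it. Compound 3 `CC(=O)n1cc(/C=C(/C(=O)O)c2ccc(OCc3ccccc3)cc2)c2cc(OCc3ccccc3)ccc21` carries two benzyloxy groups, and in this assay compound 3 gives 77700 nM. Of the two numbers available, that of compound 3 is the higher, but the gap to compound 1 is small and lies within the scatter of the method, so the two cannot be told apart.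

Compound 4 `COc1ccc(/C(=C\c2cn(C(C)=O)c3ccc(OCc4ccccc4)cc23)C(=O)O)cc1` differs from compound 3 in one place: hydrogen in place of phenyl on a saturated chain carbon bound to an oxygen on an aromatic ring. Cut one bond further out, the change reads benzyl to methyl, or benzyloxy to methoxy. Within the data shown here, no pair of measured compounds shows this exact step, so there is no direct guide. Compound 1, with 65100 nM, also carries a methoxy group and the acetyl on the ring nitrogen and sits close to compound 3, which suggests the change matters little. The expected step from compound 3 to compound 4 is therefore a 1.3-fold lower number from compound 3 to compound 4 (0.11 log units; within the scatter), no larger than the scatter. Compound 4 is estimated to give 60000 nM in this assay, within a range from 25000 nM to 150000 nM.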

Compound 4, half-maximal inhibitory concentration: 85000 nM
The estimate for compound 4 lay 1.4-fold (0.15 log units) below the measured number, within the range that was stated.
By their numbers in this assay, from the lowest: compounds 1, 3 and 4 (each within the scatter of the next).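

In this assay, hydrogen in place of phenyl on a saturated chain carbon bound to an oxygen on an aromatic ring, which turns benzyloxy into methoxy, gives a 1.1-fold higher number from compound 3 to compound 4 (0.04 log units; within the scatter); a whole six-membered aromatic ring can therefore go from this place without any difference that can be told from the scatter. Among these compounds, the first direct comparison of the methoxyphenyl forms, 4-methoxyphenyl in place of 3-methoxyphenyl, gives a 1.3-fold higher number from compound 1 to compound 4 (0.12 log units; within the scatter), so these two forms cannot be told apart in this assay either. No measured evidence offers an explanation for either result.

On these data alone, compound 2, which lacks the acetyl group on the ring nitrogen, has no number, so the step from it to compound 4 cannot be read and the part played by that acetyl group stays open. Also open, as far as these compounds go, is whether a different group in place of phenyl on that saturated chain carbon, such as an amine or a longer chain, would give a number that stands clear of the scatter around these three compounds.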